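From Cyano to Nitro on a Weak Antiproliferative Compound

The source may hold more compounds than are shown below. What is called first, only, known or untested is meant among the compounds shown, and "the series" means these compounds.

In a functional assay on VCaP cells (Homo sapiens) for antiproliferative activity, read by propidium iodide staining, with a stated time of 96 h (a lower number here means a stronger inhibitor, a higher number a weaker inhibitor), compound 1 `CC(O)(COc1cccc(C(F)(F)F)c1)C(=O)Nc1cccc(S(F)(F)(F)(F)F)c1` gives 22500 nM and compound 2 `CC1(C)C(=O)N(c2ccc(C#N)cc2C(F)(F)F)C(=S)N1c1ccc(S(F)(F)(F)(F)F)cc1` gives 100000 nM as the higher of the two numbers. Compound 2 thus stands as the weaker inhibitor of the pair, and the gap between them lies beyond the usual scatter.

Compound 3 `CC1(C)C(=O)N(c2ccc([N+](=O)[O-])cc2C(F)(F)F)C(=S)N1c1ccc(S(F)(F)(F)(F)F)cc1` keeps the rest of compound 2 but carries nitro in place of cyano on an aromatic carbon, meta to a trifluoromethyl group and para to a large group (nitro in place of cyano on an aromatic carbon). Among the compounds with values here, no two measured compounds differ in one place only, so the data hold no direct measure of a swap like this one. The expectation therefore rests on compound 2 at 100000 nM as its only starting point. The estimated change in this assay is a 1.4-fold lower number from compound 2 to compound 3 (0.15 log units; within the scatter) and no step beyond the scatter is expected, which would leave this compound among the weak inhibitors. Compound 3 is estimated at 70000 nM with an expected range from 20000 nM to 150000 nM in this measurement.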

Compound 3, half-maximal inhibitory concentration: 100000 nM
Compound 3: the middle estimate sits 1.4-fold (0.15 log units) below what was measured; the range from low to high includes it.
By their numbers in this assay, from the lowest: compound 1; then compounds 2 and 3 (each within the scatter of the next).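

In this assay, within the data shown here, the replacement of cyano by nitro on the aromatic carbon, meta to a trifluoromethyl group and para to a large group, gives no change at the digits printed from compound 2 to compound 3 (within the scatter) and is the only comparison here of compounds that differ in one place. Among these compounds, it is thus the first direct reading at this position, which the earlier compounds could not provide, and it shows that this exchange of one group for the other leaves the measured number unmoved in this weakly inhibiting pair. The material shown offers no independent measurement that could account for this outcome.

What the pair cannot settle is whether any group on this carbon matters in this assay, since both groups were read only on this one weak shared core, and a single swap does not describe the position as a whole. An amine, a carboxylic acid or a simple methyl group on the same carbon remains an open case, as does the question of whether the nitro for cyano exchange would behave the same way on a more strongly inhibiting compound.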